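From 4-hydroxyphenyl to 2-methylphenyl on the shared core

The source may hold more compounds than are shown below. What is called first, only, known or untested is meant among the compounds shown, and "the series" means these compounds.

In a functional assay on PC-3 cells (Homo sapiens) for cytotoxicity, read by sulforhodamine B assay, with a stated time of 48 h (a higher number here means a weaker inhibitor, a lower number a stronger inhibitor), compound 1 (`C[C@H]1CC[C@@H]2[C@@H](OC(=O)[C@]23CC(c2ccc(Cl)cc2)=NO3)[C@]2(C)C(=O)C=C[C@@]12O`) gives 49000 nM, compound 2 (`C[C@H]1CC[C@@H]2[C@@H](OC(=O)[C@]23CC(c2ccc(O)cc2)=NO3)[C@]2(C)C(=O)C=C[C@@]12O`) gives 20000 nM, and compound 3 (`C[C@H]1CC[C@@H]2[C@@H](OC(=O)[C@]23CC(c2ccccc2F)=NO3)[C@]2(C)C(=O)C=C[C@@]12O`) gives 8200 nM, which leaves compound 2 in the middle of the three. Compound 4 (`Cc1ccccc1C1=NO[C@]2(C1)C(=O)O[C@@H]1[C@H]2CC[C@H](C)[C@]2(O)C=CC(=O)[C@@]12C`) awaits measurement. Its change from compound 2 is 2-methylphenyl in place of 4-hydroxyphenyl on a carbon with a double bond to nitrogen, on a carbon with a double bond to nitrogen. For the measured compounds named here, the closest precedent is compound 3, which has 2-fluorophenyl in that place and shows a 2.4-fold lower number from compound 2 to compound 3 (0.39 log units; beyond the scatter). The other step at this place, a 6.0-fold lower number from compound 1 to compound 3 (0.78 log units; beyond the scatter), is also modest. A similar modest move towards a stronger inhibitor is therefore expected, with an estimated 2.0-fold lower number from compound 2 to compound 4 (0.30 log units; within the scatter). For compound 4, the expected value is 10000 nM, within an estimated range of 4000 nM to 30000 nM.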

Compound 4, half-maximal inhibitory concentration: 10000 nM
Compound 4: middle estimate and measured number agree at the digits printed, and the stated range covers the measured number.
By their numbers in this assay, from the lowest: compounds 3, 4 and 2 (each within the scatter of the next, the first and the last beyond it); then compound 1.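

In this assay, 2-methylphenyl carries no hydrogen-bond donor or acceptor, unlike 4-hydroxyphenyl, yet this change gives only a small step (a 2.0-fold lower number from compound 2 to compound 4 (0.30 log units; within the scatter)). Methyl in place of fluoro on the aromatic carbon also stays within the scatter (a 1.2-fold higher number from compound 3 to compound 4 (0.09 log units; within the scatter)), while the step from the chlorinated ring is larger and beyond it (a 4.9-fold lower number from compound 1 to compound 4 (0.69 log units; beyond the scatter)). Nothing measured here explains these numbers. From the compounds shown here alone, what remains open is how an amine, a carboxylic acid or a longer chain on this aromatic ring would read in this assay.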